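Carboxy in place of hydroxy on two related cores

The compounds below may be only part of what the source reports. "The series", "measured", "known", "first", "only" and "open" are said of these compounds alone.

Three compounds of the series have been run in a functional assay on A-375 cells (Homo sapiens) for antiproliferative activity, read by MTT assay, with a stated time of 24 h, tested at 3.7 ug/mL; on this read-out higher numbers stand for a stronger effect at the one concentration tested and lower numbers for a weaker effect. Compound 1 `CCc1ccc2nc(C(=O)Nc3c(F)cc(-c4cccc(F)c4)cc3F)c(C)c(O)c2c1` gives 17.9%. Compound 3 `CCc1ccc2nc(C(=O)Nc3c(F)cc(-c4cccc(F)c4)cc3F)c(C)c(C(=O)O)c2c1` carries the change carboxy in place of hydroxy on an aromatic carbon relative to compound 1, and compound 3 gives 26.7%, so that a number 8.8 percentage points higher from compound 1 to compound 3 (within the scatter). Compound 2 `COc1ccc2nc(C(=O)Nc3ccc(-c4ccccc4)cc3)c(C)c(O)c2c1`, on a different core, gives 27.2%; its gaps to compound 3 and to compound 1 both fall within the scatter, so no order among the three is read from these numbers. The difference between the core of compound 2 and the core of compound 1 is not broken down here.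

Compound 4 `COc1ccc2nc(C(=O)Nc3ccc(-c4ccccc4)cc3)c(C)c(C(=O)O)c2c1` has not yet been measured. It differs from compound 2 by carboxy in place of hydroxy on an aromatic carbon, the same change as that from compound 1 to compound 3, at the same place on the ring in every counted respect. This change occurs twice among the four compounds, once measured and once not.

The step expected for compound 4 in this assay is a number 4.8 percentage points higher from compound 2 to compound 4 (within the scatter). Among the compounds with values here, this rests on the single measured instance, a number 8.8 percentage points higher from compound 1 to compound 3 (within the scatter), which the scatter already covers, so little shift beyond the value of compound 2 is anticipated. Compound 4 is accordingly estimated at 32%. The range expected for compound 4 runs from 20% to 45%.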

Compound 4, a percentage reported as inhibition, at one concentration (the size of the read-out at that concentration, not a potency): 33.7%
The estimate for compound 4 lay 1.7 percentage points below the measured number; the range from low to high includes it.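

In this assay the new step, a number 6.5 percentage points higher from compound 2 to compound 4 (within the scatter), is a second reading of carboxy in place of hydroxy on an aromatic carbon, this time on the core of compound 2. Within the data shown here, neither this step nor the earlier one lies beyond the scatter, so the series does not yet show that the change has any effect of its own at the one concentration tested, and the agreement shows only that the two readings are consistent, not that a real effect carries over from one core to another. On the two cores shown, the size of the step gives no sign of depending on the core, though two cores are a narrow basis and nothing here speaks for further cores: the same change on two cores in this assay, a number 8.8 percentage points higher (within the scatter) from compound 1 to compound 3 and a number 6.5 percentage points higher (within the scatter) from compound 2 to compound 4, 2.3 percentage points apart, within the scatter of two such steps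

Open, going by these compounds, is whether any other group at this aromatic carbon, such as a methyl ester, a primary amide or an amine, would give a step beyond the scatter on either core. Also open, on these data alone, is how a longer chain in place of the methyl group would bear on the carboxy compounds, and whether the two cores would still agree at other concentrations.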